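Swapping bromo for phenyl on a weak growth inhibitor

The source may report more compounds than this note shows. Statements on the series, on what has been measured and on what is new or still open speak of the compounds shown alone.

Measured compounds:
Compound 1, `CC(=O)c1ccc(Nc2ccnc(SCC(=O)c3ccc(Br)cc3)n2)cc1`: 24%
Compound 2, `O=C(O)c1ccc(Nc2ccnc(SCC(=O)c3ccc(C(F)(F)F)cc3)n2)cc1`: 19%

Of the compounds shown here, two that share a core have been tested in a functional assay on CAKI-1 cells (Homo sapiens) for inhibition, read by sulforhodamine B assay, with a stated time of 48 h, tested at 10 uM; on this read-out higher numbers stand for more inhibition of growth at the one concentration tested and lower numbers for less inhibition of growth. Compound 1 gives 24%, and compound 2 gives 19%; the two numbers lie within the usual scatter of each other, so neither can be said to inhibit growth more than the other. Both compounds therefore show only modest inhibition at the single concentration tested.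

Compound 3, `CC(=O)c1ccc(Nc2ccnc(SCC(=O)c3ccc(-c4ccccc4)cc3)n2)cc1`, has not yet been measured. It differs from compound 1 in one place: phenyl in place of bromo on an aromatic carbon. For the measured compounds named here, no measured pair shows what such a change does here, so the expectation rests on compound 1 alone.

The step from compound 1 to compound 3 in this assay is expected to be small, with no clear direction beyond the scatter, a number 1 percentage points higher from compound 1 to compound 3 (within the scatter). Compound 3 is estimated to give 25%, with a range from 5% to 50%.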

Compound 3, percent growth inhibition at one concentration: 16%
Beside the measured number, compound 3's estimate is 9 percentage points above it, within the range that was stated.
By their numbers in this assay, from the lowest: compounds 3, 2 and 1 (each within the scatter of the next).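

In this assay, phenyl in place of bromo on an aromatic carbon gives a number 8 percentage points lower from compound 1 to compound 3 (within the scatter). For the compounds shown here, this is the first comparison here between compounds that differ in one place, and it shows that going from 1 heavy atom to 6 heavy atoms and adding an aromatic ring at this position does not separate the two compounds on this read-out. Nothing available bears on why the number behaves this way.

The compounds shown leave open whether any group at this position can move growth inhibition beyond the scatter, for example an amine or a longer alkyl chain in place of bromo. They also leave open how compound 1 and compound 3 would compare at concentrations other than the single one tested.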